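A few compounds are considered here, and "the series" means these few. Any claim that something is new, unique, unknown or untested is made for them only; others in the source may bear on it.

In a functional assay on the whole organism with Rattus norvegicus as the target (a lower number here means that less compound is needed, a higher number that more compound is needed for the effect), compound 1 (`CCOC(=O)C(=O)Nc1nc(-c2ccc(O)cc2)cs1`) gives about 15 mg/kg. Compound 3 (`CCOC(=O)C(=O)Nc1nc(-c2cccc(OC)c2)cs1`), with a different group on the aromatic ring, gives about 20 mg/kg, within the scatter of compound 1. For compound 2 (`O=C(O)C(=O)Nc1nc(-c2ccc(O)cc2)cs1`), the reading of > 3 mg/kg is a limit and not a number. Among the measured compounds shown here, the only measured step, a step that the limit leaves unreadable from compound 1 to compound 2, therefore has no readable size, and it lies elsewhere in the molecule. Compound 4 (`CCOC(=O)C(=O)Nc1nc(-c2ccc(Oc3ccccc3)cc2)cs1`) differs from compound 1 by phenyl in place of hydrogen on an oxygen on an aromatic ring. For the measured compounds named here, no measured step covers this change, so no shift beyond the scatter is expected in this assay, and the expected change is a 1.2-fold higher number from compound 1 to compound 4 (0.08 log units; within the scatter). Compound 4 is estimated at 18 mg/kg, with an expected range of 6 mg/kg to 50 mg/kg.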

Compound 4, dose for half-maximal effect: > 30 mg/kg
Compound 4: only a limit was reported (the forecaster's own chance of this, stated with the estimate: 20%); middle value at least 1.6-fold (0.22 log units) from the limit.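

In this assay compound 4 gives > 30 mg/kg and this reading is a limit, not a number. Among the compounds shown here, it is the first reading of a single change on the oxygen on the aromatic ring. Phenyl in place of hydrogen there gives an at least 2.0-fold higher number from compound 1 to compound 4 (0.30 log units; that floor lies within the scatter) and so brings no lower number, although this floor alone does not establish a loss beyond the scatter. From the compounds shown here alone, how far the number rises with phenyl remains open. So does whether an amine or a carboxylic acid in place of the hydroxy group would keep the reading of compound 1.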